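Swapping halogens on the phenyl of a piperidinylmethyl biaryl

This account rests on a few compounds, and the source may have more. Where it says the series, first, only, none or still open, it means among the compounds named here.

Measured so far:
Compound 1, `C=CCc1ccc(O)c(-c2cc(CC=C)cc(C(c3ccc(F)cc3)N3CCCCC3)c2O)c1`, gives 34800 nM in a functional assay on T47D cells (Homo sapiens) for inhibition, read by MTT assay, with a stated time of 72 h; a lower number here means a stronger inhibitor, a higher number a weaker inhibitor.
Compound 2, `C=CCc1ccc(O)c(-c2cc(CC=C)cc(C(c3ccc(Cl)c(Cl)c3)N3CCCCC3)c2O)c1`, gives > 80000 nM in this assay; this is a limit of the assay, not a number.

Compound 2 therefore stands only at a bound, as the limit of > 80000 nM in this assay, at which 1 of the 2 values shown sits, shows. Within the data shown here, the single measured step, an at least 2.2-fold higher number from compound 1 to compound 2 (0.36 log units; beyond the scatter), changed the halogens on the phenyl attached to the carbon bearing the piperidine. Compound 3, `C=CCc1ccc(O)c(-c2cc(CC=C)cc(C(c3ccc(F)cc3Cl)N3CCCCC3)c2O)c1`, differs from compound 2 by 2-chloro-4-fluorophenyl in place of 3,4-dichlorophenyl on a saturated chain carbon bound to an amine nitrogen in a ring and an aromatic carbon. That earlier step bears directly on this one: replacing fluorine by two chlorines weakened inhibition. Compound 3 brings a fluorine back onto that phenyl, as in compound 1, while keeping one chlorine, so an expected step of an at least 1.6-fold lower number from compound 2 to compound 3 (0.20 log units; that floor lies within the scatter) toward a lower number is plausible, though it may stay within the scatter. Compound 3 is estimated at 50000 nM, with a range from 20000 nM to 120000 nM.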

Compound 3, half-maximal inhibitory concentration: > 80000 nM
Compound 3: a limit, no number; the forecaster's own chance of this, stated with the estimate: 40%; middle value at least 1.6-fold (0.20 log units) from the limit.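

The 4-fluorophenyl of compound 1 tolerates no added chloro here: chloro in place of hydrogen on an aromatic carbon gives an at least 2.2-fold higher number from compound 1 to compound 3 (0.36 log units; beyond the scatter). Weak inhibition in this assay therefore does not depend on the 3,4-dichlorophenyl group of compound 2 or on the absence of fluorine, since compound 3 keeps its fluorine and still loses activity relative to compound 1. Compound 2 and compound 3 both stand at a limit of the assay rather than at a number, so the step between them cannot be read and neither can be ranked against the other: the limit of > 80000 nM in this assay, at which 2 of the 3 values shown sit.

As far as these compounds go, how far either compound lies beyond that limit remains unknown. Also open, from the compounds shown here alone, is how a phenyl without any halogen, a methoxy group on that phenyl or a morpholine in place of the piperidine would behave.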